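Switching the aryl group on the piperazine of an aminothiophene series

A few compounds are considered here, and "the series" means these few. Any claim that something is new, unique, unknown or untested is made for them only; others in the source may bear on it.

Compounds measured so far in an assay on CHO cells for displacement of a labelled ligand from adenosine receptor A1 (Homo sapiens), read by scintillation counting, with a stated time of 120 min, tested at 10 uM; on this read-out higher numbers stand for more inhibition at the one concentration tested (going by the name of the read-out) and lower numbers for less inhibition:
- compound 1 `Nc1scc(CN2CCN(c3ccc(F)cc3Cl)CC2)c1C(=O)c1ccc(Cl)cc1`: 0%
- compound 2 `Nc1scc(CN2CCN(c3ccc([N+](=O)[O-])cc3)CC2)c1C(=O)c1ccc(Cl)cc1`: 1%
- compound 3 `Nc1scc(CN2CCN(c3ccncc3)CC2)c1C(=O)c1ccc(Cl)cc1`: 1%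

Compound 3 sits level with compound 2 at the digits reported, the two of them together giving the highest of the three numbers, while compound 1 is the furthest away; the step of a number 1 percentage points higher from compound 1 to compound 3 (within the scatter) is within the scatter, as is no change at the digits printed from compound 2 to compound 3 (within the scatter) and a number 1 percentage points higher from compound 1 to compound 2 (within the scatter). In effect, all three compounds show essentially no displacement at the single concentration tested.

Compound 4 `Nc1scc(CN2CCN(c3ccccc3F)CC2)c1C(=O)c1ccc(Cl)cc1` differs from compound 3 as follows: 2-fluorophenyl in place of pyridin-4-yl on an amine nitrogen in a ring. Among the compounds with values here, the steps that bear on this change are those that also exchange the aryl group on the same ring nitrogen, namely a number 1 percentage points higher from compound 1 to compound 3 (within the scatter) and no change at the digits printed from compound 2 to compound 3 (within the scatter), both within the scatter. Since exchanging a halogenated phenyl, a nitrophenyl and a pyridinyl at this position left the read-out unmoved, no step beyond the scatter in this assay is expected for the return to a halogenated phenyl here.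

Compound 4 is therefore estimated at 1%, within a range of -8% to 12%, an expected step of no change at the digits printed from compound 3 to compound 4 (within the scatter).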

Compound 4, a percentage reported as inhibition, at one concentration (the size of the read-out at that concentration, not a potency): 4%
Estimate against measurement, compound 4: 3 percentage points below, and the stated range covers the measured number.
By their numbers in this assay, from the lowest: compounds 1, 2, 3 and 4 (each within the scatter of the next).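

In this assay, the carbon-only 2-fluorophenyl ring, counted with no hydrogen-bond acceptor, takes the place of the pyridin-4-yl ring, counted with one, and the step stays small (a number 3 percentage points higher from compound 3 to compound 4 (within the scatter)). The same holds against the other two aryl groups (a number 3 percentage points higher from compound 2 to compound 4 (within the scatter)) and (a number 4 percentage points higher from compound 1 to compound 4 (within the scatter)), so all four aryl groups on this ring nitrogen now give numbers within the scatter of one another, and none shows appreciable displacement at the one concentration tested. No supporting data bear on why this position stays so flat.

The compounds shown leave open whether a non-aromatic group on this nitrogen, such as a benzyl or cyclohexyl group, would shift the read-out. They also leave open whether replacing the 4-chlorophenyl on the carbonyl with another group would do so.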